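Four Compounds from One Series Against HepG2 Cells

A few compounds are considered here, and "the series" means these few. Any claim that something is new, unique, unknown or untested is made for them only; others in the source may bear on it.

Compound 1 `COc1cc(-c2nc3ccccc3s2)ccc1OCC(=O)NNC(=O)CN[C@@H](CS(=O)(=O)O)C(=O)O`, compound 2 `COc1cc(-c2nc3ccccc3s2)ccc1OCC(=O)NNC(=O)CN[C@@H](CCSC)C(=O)O` and compound 3 `CCOC(=O)[C@H](CS(=O)(=O)O)NCC(=O)NNC(=O)COc1ccc(-c2nc3ccccc3s2)cc1OC` have been tested in a functional assay on HepG2 cells (Homo sapiens) for inhibition, read by MTT assay, with a stated time of 3 days; on this read-out higher numbers stand for weaker inhibition and lower numbers for stronger inhibition. In this assay compound 1 gives 3690 nM, compound 2 gives 3780 nM and compound 3 gives 3360 nM. Compound 2 differs from compound 1 by (methylsulfanyl)methyl in place of sulfo on a saturated chain carbon, two bonds along the chain from an amine nitrogen and a carbonyl carbon, a change that made a 1.0-fold higher number from compound 1 to compound 2 (0.01 log units; within the scatter). Compound 3 differs from compound 1 by ethyl in place of hydrogen on an oxygen next to a carbonyl group, and that change made a 1.1-fold lower number from compound 1 to compound 3 (0.04 log units; within the scatter). Compound 4 `CCOC(=O)[C@H](CCSC)NCC(=O)NNC(=O)COc1ccc(-c2nc3ccccc3s2)cc1OC` is not yet measured. It differs from compound 3 by (methylsulfanyl)methyl in place of sulfo on a saturated chain carbon, two bonds along the chain from an amine nitrogen and a carbonyl carbon, the same change, at the same place, as from compound 1 to compound 2. In this assay, resting on a 1.0-fold higher number from compound 1 to compound 2 (0.01 log units; within the scatter), compound 4 is expected to give a 1.0-fold higher number from compound 3 to compound 4 (0.01 log units; within the scatter). The estimate for compound 4 is 3400 nM, with a lower end of 1700 nM and an upper end of 6800 nM.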

Compound 4, half-maximal inhibitory concentration: 3330 nM
The estimate for compound 4 lay 1.0-fold (0.01 log units) above the measured number; the measured number falls inside the stated range.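

In this assay, (methylsulfanyl)methyl in place of sulfo on the ethyl ester gave a 1.0-fold lower number from compound 3 to compound 4 (0.00 log units; within the scatter), which matches the earlier step on the free acid: the same change on two cores in this assay, a 1.0-fold higher number (0.01 log units; within the scatter) from compound 1 to compound 2 and a 1.0-fold lower number (0.00 log units; within the scatter) from compound 3 to compound 4, 1.0-fold (0.01 log units) apart, within the scatter of two such steps. Ethyl in place of hydrogen on the oxygen gave a 1.1-fold lower number from compound 2 to compound 4 (0.06 log units; within the scatter), and exchanging both groups together gave a 1.1-fold lower number from compound 1 to compound 4 (0.04 log units; within the scatter), so this change also carried across: the same change on two cores in this assay, a 1.1-fold lower number (0.04 log units; within the scatter) from compound 1 to compound 3 and a 1.1-fold lower number (0.06 log units; within the scatter) from compound 2 to compound 4, 1.0-fold (0.01 log units) apart, within the scatter of two such steps. This shows that each change left the number within the scatter on both cores, but it does not show that an effect of real size would carry from one core to another, since neither change produced one here.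

The compounds shown leave open whether an amine or a longer chain on that saturated chain carbon, or a benzyl group in place of the ethyl, would shift the number at all.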